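The source may report more compounds than this note shows. Statements on the series, on what has been measured and on what is new or still open speak of the compounds shown alone.

The series shares one core, a benzophenone bearing a trimethoxyphenyl ring on one side and, on the other, an aryl ring that carries a cinnamide. Compound 1 `COc1ccc(C(=O)c2cc(OC)c(OC)c(OC)c2)cc1NC(=O)/C=C/c1ccc(F)c(F)c1` carries a difluorophenyl ring on that cinnamide. In a functional assay on HeLa cells (Homo sapiens) for cytotoxicity, read by MTT assay, with a stated time of 72 h (on this read-out lower numbers stand for stronger inhibition and higher numbers for weaker inhibition), compound 1 gives 8100 nM. Compound 2 `COc1ccc(/C=C/C(=O)Nc2cc(C(=O)c3cc(OC)c(OC)c(OC)c3)cc(OC)c2OC)cc1OC` instead carries a 3,4-dimethoxyphenyl ring there, and in this assay compound 2 gives 2700 nM. For the measured compounds named here, of the two numbers so far, the number of compound 2 is the lowest, and compound 1 stands a good deal higher, beyond the usual scatter of such measurements.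

Compound 3 `COc1ccc(/C=C/C(=O)Nc2cc(C(=O)c3cc(OC)c(OC)c(OC)c3)cc(OC)c2OC)cc1N` is a close relative of compound 2. The change is amino in place of methoxy on an aromatic carbon, so the 2-(3,4-dimethoxyphenyl)ethenyl arm becomes a 2-(3-amino-4-methoxyphenyl)ethenyl arm. Going by the values given here, no pair of measured compounds shows this change, so nothing measured here tells how large its effect will be. My expectation is a small step in this assay, if any, from compound 2 to compound 3, not clearly beyond the scatter and on balance toward a slightly lower number, which is what a 1.4-fold lower number from compound 2 to compound 3 (0.13 log units; within the scatter) expresses. For compound 3 the estimate is 2000 nM, with a plausible range from 700 nM to 6000 nM.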

Compound 3, half-maximal inhibitory concentration: 15800 nM
Compound 3: the middle estimate sits 7.9-fold (0.90 log units) below what was measured; the measured number lies above the stated range.
By their numbers in this assay, from the lowest: compound 2; then compounds 1 and 3 (each within the scatter of the next).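

In this assay, putting amino in place of methoxy on this aromatic carbon, ortho to a methoxy group, gives a 5.9-fold higher number from compound 2 to compound 3 (0.77 log units; beyond the scatter). This is the only pair shown that differs in one place, and it shows that the read-out responds to a single change at this carbon, in the direction of weaker inhibition. The exchange removes a group with no hydrogen-bond donor and brings in one with a hydrogen-bond donor, but nothing available explains why the number moves as it does.

A single pair cannot separate the effect of losing the methoxy group from the effect of gaining the amino group, so the compounds shown leave open which of the two matters here. A hydroxyl group, a dimethylamino group or a plain hydrogen on this same carbon would help to tell these apart, and the same exchange on a different core would show whether the step holds beyond this one pair.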